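Estimating Cytotoxicity for Compound 4 After One Group Swap

The compounds below may be only part of what the source reports. "The series", "measured", "known", "first", "only" and "open" are said of these compounds alone.

Measured in an ADME assay on HEK-293T cells (Homo sapiens) for cytotoxicity, read by CCK-8 assay, with a stated time of 48 h (on this read-out higher numbers stand for weaker inhibition and lower numbers for stronger inhibition), each value being a limit and not a number:
- Compound 1 `Nc1ccc(Oc2ccccc2-c2ccc(S(=O)(=O)NCCNC(=O)Nc3ccc(Cl)cc3)s2)cc1` gives > 20000 nM (a limit)
- Compound 2 `COc1cccc(NC(=S)NCCNS(=O)(=O)c2ccc(-c3ccccc3Oc3ccc([N+](=O)[O-])cc3)s2)c1` gives > 20000 nM (a limit)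
- Compound 3 `O=S(=O)(c1sccc1-c1ccccc1Oc1ccc(O)c(O)c1)N1CCN(C(=S)Nc2ccc(Cl)cc2)CC1` gives > 50000 nM (a limit)

Compound 1 stands at the limit of > 20000 nM in this assay, at which 2 of the 3 values shown sit, and has no exact number. Compound 3 stands at the limit of > 50000 nM in this assay, at which 1 of the 3 values shown sits, and has no exact number either. Compound 4 `O=C(NCCNS(=O)(=O)c1ccc(-c2ccccc2Oc2ccc([N+](=O)[O-])c([N+](=O)[O-])c2)s1)Nc1ccc(Cl)cc1` has not yet been measured. It differs from compound 1 by a single swap 3,4-dinitrophenyl in place of 4-aminophenyl on an oxygen on an aromatic ring with 3,4-dinitrophenyl in place of 4-aminophenyl on an oxygen on an aromatic ring.

Among the measured compounds shown here, no two measured compounds differ in just one place, so in this assay the data give no size for such a step. The expectation is therefore no step beyond the scatter, with no direction favoured. It rests on compound 1 with its limit of > 20000 nM as the only starting point. The expected change is a number no higher from compound 1 to compound 4 (the limit leaves the size open) and this remains an estimate. For compound 4 the estimated value is 20000 nM with an expected range from 8000 nM to 50000 nM in this estimate.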

Compound 4, half-maximal inhibitory concentration: > 20000 nM
Compound 4: no number, only a limit; the forecaster's own chance of this, stated with the estimate: 55%; the middle value sits exactly at the limit.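

In this assay compound 4 gives > 20000 nM, which is a limit and not a number. Compound 1 gives > 20000 nM, also a limit. Among the compounds shown here, no step between compound 1 and compound 4 can be read. The compounds shown leave open what size of change, if any, 3,4-dinitrophenyl in place of 4-aminophenyl brings to cytotoxicity.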